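Thiazole in place of chlorothiophene on the ketone of compound 3

A few compounds are considered here, and "the series" means these few. Any claim that something is new, unique, unknown or untested is made for them only; others in the source may bear on it.

Three compounds have been run in a functional assay on CHO-K1 cells for antagonist activity at adenosine receptor A2b (Homo sapiens), read by FLIPR and calcium flux; on this read-out higher numbers stand for weaker inhibition and lower numbers for stronger inhibition. Compound 1 `Cc1nc(C(=O)c2ccc(C)s2)c2sccc2n1` reaches only the limit (the limit of > 10000 nM in this assay, at which 1 of the 3 values shown sits), reported as > 10000 nM. Among the measured compounds shown here, compound 2 `CCc1nc(C(=O)c2ccc(C)s2)c2sccc2n1` gives 3670 nM, and the step of an at least 2.7-fold lower number from compound 1 to compound 2 (0.43 log units; beyond the scatter) is the only measured step. Compound 3 `O=C(c1ccc(Cl)s1)c1nc(NCc2cccnc2)nc2ccsc12` gives 487 nM, the lowest of the two numbers, with compound 2 the nearest. Compound 4 `O=C(c1nccs1)c1nc(NCc2cccnc2)nc2ccsc12` differs from compound 3 by 1,3-thiazol-2-yl in place of 5-chlorothiophen-2-yl on a carbonyl carbon. For the measured compounds named here, no measured step touches the carbonyl carbon; the one measured step sits on a saturated chain carbon, so it gives no guide to direction or size here. The expected step of a 1.6-fold higher number from compound 3 to compound 4 (0.22 log units; within the scatter) is therefore none beyond the scatter, with a wide range around it. Compound 4 is estimated at 800 nM, between 200 nM and 3500 nM.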

Compound 4, half-maximal inhibitory concentration: 176 nM
Compound 4: middle estimate off by 4.5-fold (0.66 log units), on the high side; measured number below the stated range.
By their numbers in this assay, from the lowest: compound 4; then compound 3; then compound 2. At a limit, above all of these: compound 1.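

In this assay the carbonyl substituent proves able to shift the number, with 1,3-thiazol-2-yl in place of 5-chlorothiophen-2-yl giving a 2.8-fold lower number from compound 3 to compound 4 (0.44 log units; beyond the scatter). The chlorine is therefore not required for a number of this size on this core. Nothing measured here accounts for the change. As far as these compounds go, whether the shift follows the added ring nitrogen or the lost chlorine stays open, since both change in this single step. A plain thiophen-2-yl or a phenyl on the carbonyl would bear on that question.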